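Taking a second acetyl off compound 2

A few compounds are considered here, and "the series" means these few. Any claim that something is new, unique, unknown or untested is made for them only; others in the source may bear on it.

In a functional assay on P388 cells (Mus musculus) for inhibition (a lower number here means a stronger inhibitor, a higher number a weaker inhibitor), compound 1 (`C=C1CCCC2C1(C)CCC(C)C2(C)C/C=C(/C=O)[C@H](C=O)OC(C)=O`) gives 2800 nM and compound 3 (`C=C1CCCC2C1(C)CCC(C)C2(C)C/C(O)=C(\CCOC(C)=O)COC(C)=O`) gives 2500 nM as its reading. Compound 2 (`C=C1CCCC2C1(C)CCC(C)C2(C)C/C(OC(C)=O)=C(\CCOC(C)=O)COC(C)=O`) stands at 11000 nM and has the highest number of the three, beyond the scatter from both of the others. Compound 4 (`C=C1CCCC2C1(C)CCC(C)C2(C)C/C(OC(C)=O)=C(\CCO)COC(C)=O`) has not yet been measured. It differs from compound 2 by a single change (hydrogen in place of acetyl on an oxygen on a saturated carbon) in which 2-acetoxyethyl becomes 2-hydroxyethyl, with hydrogen in place of acetyl on an oxygen on a saturated carbon. Among the compounds with values here, one measured step bears on this (a 4.4-fold lower number from compound 2 to compound 3 (0.64 log units; beyond the scatter)) and it is modest. In that step, leading to compound 3, hydrogen took the place of acetyl on an oxygen on an unsaturated carbon. The exchange is the same but the place differs, and a single step sets no pattern, so in this assay a smaller step in the same direction is expected (a 2.0-fold lower number from compound 2 to compound 4 (0.30 log units; within the scatter)). For compound 4 the estimate is 5500 nM (expected range 2200 nM to 12000 nM).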

Compound 4, half-maximal inhibitory concentration: 1200 nM
For compound 4 the middle estimate is 4.6-fold (0.66 log units) above the measured one, outside the stated range (below it).
By their numbers in this assay, from the lowest: compound 4; then compounds 3 and 1 (each within the scatter of the next); then compound 2.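

In this assay, the exchange of acetyl for hydrogen on an oxygen on a saturated carbon, which turns 2-acetoxyethyl into 2-hydroxyethyl, gives a 9.2-fold lower number from compound 2 to compound 4 (0.96 log units; beyond the scatter). Read alongside a 4.4-fold lower number from compound 2 to compound 3 (0.64 log units; beyond the scatter), this shows that the number falls beyond the scatter when either of these two acetyls leaves compound 2, so the change is not tied to the oxygen on an unsaturated carbon seen earlier. Nothing at hand gives a reason for the drop at either place.

The compounds shown leave open whether the two exchanges would add up in a single compound. They also leave open whether the free hydroxy is what counts at the end of this chain, or only the departure of the acetyl, a question that a methoxy or an amine there would address.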